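The compounds below may be only part of what the source reports. "The series", "measured", "known", "first", "only" and "open" are said of these compounds alone.

Three hydrazine-linked compounds sharing one core were measured in a functional assay on OVCAR-3 cells (Homo sapiens) for antiproliferative activity, read by sulforhodamine B assay, with a stated time of 72 h; a higher number here means a weaker inhibitor, a lower number a stronger inhibitor. Compound 1 `Cc1ccc(C(/C=C/c2ccc(F)cc2)=N\Nc2nncc3ccccc23)cc1` gives 4.5 nM in this assay. Compound 2 `O=C1CS/C(=N/Nc2nncc3ccccc23)N1c1ccccc1` gives 44 nM, and compound 3 `NC(=S)NNc1nncc2ccccc12` gives 74 nM. Among these three numbers compound 2 holds the second highest. Its value and that of compound 3 lie within the usual scatter of each other, so no order between those two can be read from this assay. The gap to compound 1 is different: compound 1 has a clearly lower number, beyond the scatter, and so inhibits growth more strongly than compound 2.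

Compound 4 `O=C1CS/C(=N/Nc2nncc3ccccc23)N1` has not yet been measured in this assay. It differs from compound 2 in one place: hydrogen in place of phenyl on an amide-type nitrogen in a ring. The phenyl leaves and a hydrogen enters on the amide-type nitrogen in the ring.

Within the data shown here, no measured pair shows this exact change, so the size of the step is open. Because compound 1, which carries the largest aryl portion, gives 4.5 nM while the smallest compound 3 gives 74 nM, a modest weakening is expected on removing the phenyl. The expected step is a 2.7-fold higher number from compound 2 to compound 4 (0.44 log units; beyond the scatter), an upward move that may or may not exceed the scatter. Compound 4 is estimated at 120 nM in this assay, with a range from 40 nM to 400 nM.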

Compound 4, half-maximal inhibitory concentration: 46 nM
Compound 4: the middle estimate sits 2.6-fold (0.42 log units) above what was measured; the measured number falls inside the stated range.
By their numbers in this assay, from the lowest: compound 1; then compounds 2, 4 and 3 (each within the scatter of the next).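

Among these compounds, compound 2 and compound 4 form the first pair in this set that differs in one place, so the phenyl on the amide-type nitrogen in the ring can now be judged directly rather than inferred from compounds differing in several places. In this assay, replacing that phenyl with hydrogen gives a 1.0-fold higher number from compound 2 to compound 4 (0.02 log units; within the scatter), so the two compounds cannot be told apart, and the six carbon atoms and aromatic ring of the phenyl make no measurable difference to the number in this pair. Nothing given here explains this result.

As far as these compounds go, what other groups on this nitrogen would give remains open: a methyl, a longer chain such as butyl, a benzyl, or a chain ending in an amine or a carboxylic acid could each read like hydrogen and phenyl or could depart from them. A single pair also cannot say whether the same exchange would read alike on a different core, or whether hydrogen and phenyl would stay equivalent if another part of compound 2 were altered.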